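This account rests on a few compounds, and the source may have more. Where it says the series, first, only, none or still open, it means among the compounds named here.

Measured compounds:
- compound 1 `N#CC1=C(N)Oc2c(N)cc3nc4ccccc4nc3c2C12C(=O)N(Cc1cnnn1-c1ccc(F)cc1)c1ccccc12`, a limit in a functional assay on MCF7 cells (Homo sapiens) for antiproliferative activity, read by MTT assay, with a stated time of 48 h; a lower number here means a stronger inhibitor, a higher number a weaker inhibitor: > 50000 nM
- compound 2 `N#CC1=C(N)Oc2c(N)cc3nc4ccccc4nc3c2C12C(=O)N(Cc1cnnn1-c1c(F)cccc1F)c1ccccc12`, also a limit: > 50000 nM
- compound 3 `N#CC1=C(N)Oc2c(N)cc3nc4ccccc4nc3c2C12C(=O)N(Cc1cnnn1-c1ccc(F)c(Cl)c1)c1ccccc12`: 17800 nM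

Compound 3 is the only one of the three that gives a number in this assay; the other two values sit at a limit of the assay (the limit of > 50000 nM in this assay, at which 2 of the 3 values shown sit). The value of compound 1 is such a limit, > 50000 nM. The value of compound 2 is likewise a limit, > 50000 nM. Two measured steps point toward compound 3: an at least 2.8-fold lower number from compound 1 to compound 3 (0.44 log units; beyond the scatter), and an at least 2.8-fold lower number from compound 2 to compound 3 (0.44 log units; beyond the scatter). The step that the two limits leave unreadable from compound 1 to compound 2 cannot be read.

Compound 4 `N#CC1=C(N)Oc2c(N)cc3nc4ccccc4nc3c2C12C(=O)N(Cc1cnnn1-c1ccc([N+](=O)[O-])cc1[N+](=O)[O-])c1ccccc12` differs from compound 3 by 2,4-dinitrophenyl in place of 3-chloro-4-fluorophenyl on an aromatic nitrogen. Among the compounds with values here, no measured step exchanges the phenyl on the aromatic nitrogen for a dinitrophenyl, so the two steps toward compound 3 bear on it only loosely: both show that a change of this phenyl can move the number by at least a modest amount. The step from compound 3 to compound 4 is expected to be a 1.4-fold higher number from compound 3 to compound 4 (0.15 log units; within the scatter), with the number drifting back toward the limit. Compound 4 is estimated at 25000 nM, between 6000 nM and 100000 nM.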

Compound 4, half-maximal inhibitory concentration: 20900 nM
The estimate for compound 4 lay 1.2-fold (0.08 log units) above the measured number; the range from low to high includes it.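

In this assay, the 2,4-dinitrophenyl group of compound 4 gives a second readable number on this aromatic nitrogen, and it shares no substituent with the 3-chloro-4-fluorophenyl group: a 1.2-fold higher number from compound 3 to compound 4 (0.07 log units; within the scatter). Against the two fluorophenyl groups, the same exchange gives an at least 2.3-fold lower number from compound 2 to compound 4 (0.37 log units; beyond the scatter) and an at least 2.3-fold lower number from compound 1 to compound 4 (0.37 log units; beyond the scatter). Two differently substituted phenyl groups thus give numbers within the scatter of each other, while the two phenyl groups carrying only fluorine stay out of reach of a number, so these two steps are only bounds and the step between compound 1 and compound 2 cannot be read: the limit of > 50000 nM in this assay, at which 2 of the 4 values shown sit.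

The compounds shown do not tell whether one nitro group alone would give the same number as the two in compound 4. They also leave open how an unsubstituted phenyl, an amine or a carboxylic acid at this place would read.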